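The compounds below may be only part of what the source reports. "The series", "measured", "known", "first", "only" and "open" are said of these compounds alone.

Compound 1 `Cn1c(=O)c2nc(-c3cccc(F)c3)[nH]c2n(C)c1=O` and compound 2 `Cn1c(=O)c2nc(-c3cccc([N+](=O)[O-])c3)[nH]c2n(C)c1=O` share one core and differ by nitro in place of fluoro on an aromatic carbon. In an assay for binding affinity to adenosine receptor A1 (Bos taurus) (a lower number here means a stronger inhibitor, a higher number a weaker inhibitor), compound 1 gives 4 nM, and compound 2 gives 50 nM; this is a 13-fold higher number from compound 1 to compound 2 (1.10 log units; beyond the scatter). Compound 3 `Cn1c(=O)c2nc(-c3ccc(F)cc3)[nH]c2n(C)c1=O` gives 3.5 nM in this assay; how the core of compound 3 differs from that of compound 1 is not broken down here, and the two values lie within the scatter of each other. Compound 4 `Cn1c(=O)c2nc(-c3ccc([N+](=O)[O-])cc3)[nH]c2n(C)c1=O` is not yet measured in this assay. It differs from compound 3 by nitro in place of fluoro on an aromatic carbon, the same kind of change as that between compound 1 and compound 2, with a different place: there meta to a large group, here para to a large group. Among the measured compounds shown here, the expected step of a 13-fold higher number from compound 3 to compound 4 (1.11 log units; beyond the scatter) rests on the one earlier instance, a 13-fold higher number from compound 1 to compound 2 (1.10 log units; beyond the scatter). Compound 4 is therefore estimated at 45 nM, between 12 nM and 170 nM.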

Compound 4, half-maximal inhibitory concentration: 8 nM
Compound 4: middle estimate off by 5.6-fold (0.75 log units), on the high side, and the stated range ends above it.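

Nitro in place of fluoro gives a 2.3-fold higher number from compound 3 to compound 4 (0.36 log units; beyond the scatter) in this assay, a step in the same direction as the earlier one. The size of the step does not carry over from one core to the other: the same change on two cores in this assay, a 13-fold higher number (1.10 log units; beyond the scatter) from compound 1 to compound 2 and a 2.3-fold higher number (0.36 log units; beyond the scatter) from compound 3 to compound 4, 5.5-fold (0.74 log units) apart, beyond the scatter of two such steps. These two pairs show a shared direction and an unequal size, but they do not show what sets the size, or whether the change on a further core would follow either step.

Still open, on these data alone, is how an amine, a carboxylic acid or a methoxy group para to a large group would compare with fluoro and nitro. Also open, as far as these compounds go, is whether such groups would give steps of different size on the two cores.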